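Compound 2 to compound 3: swapping the amide end group

This account rests on a few compounds, and the source may have more. Where it says the series, first, only, none or still open, it means among the compounds named here.

In a functional assay on HepG2 cells (Homo sapiens) for antiproliferative activity, read by CCK-8 assay, with a stated time of 72 h (on this read-out lower numbers stand for stronger inhibition and higher numbers for weaker inhibition), compound 1 `O=C(NO)c1ccc(COc2ccccc2)cc1` gives 29600 nM. Compound 2 `Nc1cnccc1NC(=O)/C=C/c1ccc(COc2ccccc2)cc1` stands at > 32000 nM in this assay, which is a limit of the assay and not a number. Compound 3 `O=C(/C=C/c1ccc(COc2ccccc2)cc1)NO` differs from compound 2 by hydroxy in place of 3-aminopyridin-4-yl on an amide-type nitrogen, with hydroxy in place of 3-aminopyridin-4-yl on an amide-type nitrogen. Compound 1 also carries hydroxyamino and reads 29600 nM, so a number rather than a limit is expected. The expected change is an at least 3.5-fold lower number from compound 2 to compound 3 (0.55 log units; beyond the scatter), a moderate step towards stronger inhibition. For compound 3 the estimated value is 9000 nM, with an expected range of 2000 nM to 32000 nM.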

Compound 3, half-maximal inhibitory concentration: 8400 nM
Estimate against measurement, compound 3: 1.1-fold (0.03 log units) above; the measured number falls inside the stated range.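

In this assay, hydroxy in place of 3-aminopyridin-4-yl on an amide-type nitrogen gives an at least 3.8-fold lower number from compound 2 to compound 3 (0.58 log units; beyond the scatter). The size of that step remains a bound, since compound 2 stands at a limit of the assay and not a number: the limit of > 32000 nM in this assay, at which 1 of the 3 values shown sits.

For the compounds shown here, with the hydroxyamino end kept, 2-(hydroxycarbamoyl)ethenyl in place of hydroxycarbamoyl on an aromatic carbon gives a 3.5-fold lower number from compound 1 to compound 3 (0.55 log units; beyond the scatter), the first step read between two numbers.

Open, as far as these compounds go, is whether a carboxylic acid or a primary amide at this end would hold the number of compound 3. Also open, from the compounds shown here alone, is what a longer chain in place of the ethenyl link would do.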